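This account rests on a few compounds, and the source may have more. Where it says the series, first, only, none or still open, it means among the compounds named here.

Compound 1 `COC(=O)c1cccc(-c2cc(C(=O)Nc3ccncc3)ccc2CN)c1` gives 2.9 nM in an assay on isolated protein for inhibition of Rho-associated protein kinase 2 (Homo sapiens), read by radiometric assay; a higher number here means a weaker inhibitor, a lower number a stronger inhibitor. Compound 2 `CCCCCCOC(=O)c1cccc(-c2cc(C(=O)Nc3ccncc3)ccc2CN)c1` gives 22 nM. Compound 3 `CCCCOC(=O)c1cccc(-c2cc(C(=O)Nc3ccncc3)ccc2CN)c1` gives 5.5 nM.

Compound 3 stands second highest of the three numbers, close to compound 1 and further from compound 2. Compound 4 `NCc1ccc(C(=O)Nc2ccncc2)cc1-c1cccc(C(=O)OCC2CCCC2)c1` differs from it by cyclopentyl in place of propyl on a saturated chain carbon bound to an oxygen next to a carbonyl group. Going by the values given here, the steps that bear on this are a 1.9-fold higher number from compound 1 to compound 3 (0.28 log units; within the scatter), a 7.6-fold higher number from compound 1 to compound 2 (0.88 log units; beyond the scatter) and a 4.0-fold lower number from compound 2 to compound 3 (0.60 log units; beyond the scatter): lengthening the chain at this place costs potency once it goes beyond propyl. Cyclopentyl adds more carbon than propyl, so a modest rise in the number is expected, a 2.2-fold higher number from compound 3 to compound 4 (0.34 log units; beyond the scatter). Compound 4 is therefore estimated at 12 nM, between 5 nM and 30 nM.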

Compound 4, half-maximal inhibitory concentration: 5 nM
Beside the measured number, compound 4's estimate is 2.4-fold (0.38 log units) above it; low and high end bracket the measured number.
By their numbers in this assay, from the lowest: compounds 1, 4 and 3 (each within the scatter of the next); then compound 2.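

In this assay, compound 4 stays within the scatter of the shorter esters, a 1.1-fold lower number from compound 3 to compound 4 (0.04 log units; within the scatter) and a 1.7-fold higher number from compound 1 to compound 4 (0.24 log units; within the scatter), yet clears the long open chain, a 4.4-fold lower number from compound 2 to compound 4 (0.64 log units; beyond the scatter). At this place, then, the number does not simply follow added carbon: among these four compounds, cyclopentyl costs nothing measurable, while pentyl does. Nothing measured here explains this difference. On these data alone, whether a cyclohexyl or phenyl ring would match cyclopentyl remains open, as does how an amine or a carboxylic acid on this chain would fare.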